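A New Sulfur Side Chain After Compound 3

A few compounds are considered here, and "the series" means these few. Any claim that something is new, unique, unknown or untested is made for them only; others in the source may bear on it.

In a functional assay on HT cells (Homo sapiens) for antiproliferative activity, read by fluorescence, with a stated time of 72 h (a higher number here means a weaker inhibitor of growth, a lower number a stronger inhibitor of growth), compound 1 `CSc1nc(NCc2ccc(-c3ccccn3)cc2)c2[nH]nc(C(C)C)c2n1` gives 783 nM, compound 2 `CC(C)c1n[nH]c2c(NCc3ccc(-c4ccccn4)cc3)nc(SCCCO)nc12` gives 109 nM and compound 3 `CC(C)c1n[nH]c2c(NCc3ccc(-c4ccccn4)cc3)nc(SCC(N)=O)nc12` gives 192 nM. Compound 3 therefore sits within the scatter of compound 2 and clearly apart from compound 1.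

Compound 4 `CSCCSc1nc(NCc2ccc(-c3ccccn3)cc2)c2[nH]nc(C(C)C)c2n1` carries (methylsulfanyl)methyl in place of carbamoyl on a saturated chain carbon bound to a sulfur. For the measured compounds named here, three measured steps bear on this change. Placing a group on that carbon gave a 7.2-fold lower number from compound 1 to compound 2 (0.86 log units; beyond the scatter) and a 4.1-fold lower number from compound 1 to compound 3 (0.61 log units; beyond the scatter), both modest and beyond the scatter. Exchanging one of these groups for the other gave a 1.8-fold higher number from compound 2 to compound 3 (0.25 log units; within the scatter), which is within the scatter. Going by the values given here, no measured compound carries the entering group, so the evidence is indirect.

These steps suggest that the group on this carbon may be varied with little effect, though compound 4 could drift towards compound 1. The expected result in this assay is a 1.3-fold higher number from compound 3 to compound 4 (0.11 log units; within the scatter), a small rise that is not expected to exceed the scatter. Compound 4 is estimated at 250 nM, with an expected range from 110 nM to 570 nM.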

Compound 4, concentration for 50% growth inhibition: 975 nM
Estimate against measurement, compound 4: 3.9-fold (0.59 log units) below; measured number above the stated range.
By their numbers in this assay, from the lowest: compounds 2 and 3 (each within the scatter of the next); then compounds 1 and 4 (each within the scatter of the next).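

In this assay the group on this carbon proved not to be freely exchangeable: (methylsulfanyl)methyl in place of carbamoyl gave a 5.1-fold higher number from compound 3 to compound 4 (0.71 log units; beyond the scatter) and methylsulfanyl in place of hydroxymethyl gave an 8.9-fold higher number from compound 2 to compound 4 (0.95 log units; beyond the scatter) with both steps beyond the scatter. Set against hydrogen on the same carbon, (methylsulfanyl)methyl gave a 1.2-fold higher number from compound 1 to compound 4 (0.10 log units; within the scatter) and stayed within the scatter, so a group on this carbon does not by itself lower the number. Among these four compounds, the lower numbers belong only to compound 2 and compound 3, whose chains end in hydroxymethyl and carbamoyl, while compound 1 and compound 4 carry neither group.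

Nothing shown here explains why the methylsulfanyl end differs from these two groups. From the compounds shown here alone, it also remains open whether a chain ending in an amine or a carboxylic acid, or a longer chain ending in hydroxymethyl, would keep the lower numbers.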